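Swapping One Fluorophenyl for Another

This account rests on a few compounds, and the source may have more. Where it says the series, first, only, none or still open, it means among the compounds named here.

In a functional assay on OVCAR-5 cells (Homo sapiens) for inhibition, read by CCK-8 assay, with a stated time of 72 h, tested at 10 uM (on this read-out lower numbers stand for less inhibition of growth and higher numbers for more inhibition of growth at the one concentration tested), compound 1 `CN(C)C(=O)c1cc2cnc(Nc3ccc(NC(=O)C4(C(=O)Nc5ccc(F)cc5)CC4)cc3)nc2n1C1CCCC1` gives 79.7% and compound 2 `CN(C)C(=O)c1cc2cnc(Nc3ccc(NC(=O)C4(C(=O)Nc5cccc(F)c5)CC4)cc3)nc2n1C1CCCC1` gives 85.6%, two numbers within the usual scatter of each other, so compound 2 stands level with compound 1. Compound 3 `CN(C)C(=O)c1cc2cnc(Nc3ccc(NC(=O)C4(C(=O)Nc5ccccc5F)CC4)cc3)nc2n1C1CCCC1` keeps the shared core and differs from compound 2 in one place: 2-fluorophenyl in place of 3-fluorophenyl on an amide-type nitrogen. In words, it carries 2-fluorophenyl in place of 3-fluorophenyl on an amide-type nitrogen. Among the compounds with values here, one measured step bears on this change: a number 5.9 percentage points higher from compound 1 to compound 2 (within the scatter), where 3-fluorophenyl replaced 4-fluorophenyl on an amide-type nitrogen. Within the data shown here, that step lies within the scatter, and it is only a single example. No step beyond the scatter is therefore expected in this assay, and the expected change is a number 3.6 percentage points lower from compound 2 to compound 3 (within the scatter). Compound 3 is estimated to give 82% (expected range 70% to 92%) .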

Compound 3, percent growth inhibition at one concentration: 82.6%
Estimate against measurement, compound 3: 0.6 percentage points below, and the stated range covers the measured number.
By their numbers in this assay, from the lowest: compounds 1, 3 and 2 (each within the scatter of the next).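

With 2-fluorophenyl now on the amide-type nitrogen, the set holds 2-, 3- and 4-fluorophenyl side by side in this assay, and the two new comparisons read a number 3 percentage points lower from compound 2 to compound 3 (within the scatter) and a number 2.9 percentage points higher from compound 1 to compound 3 (within the scatter). Within the data shown here, the earlier pair covered only two of these groups, whereas all three now fall within the scatter of one another, so this read-out at a single concentration does not separate them. Nothing available here offers an explanation for how closely the three compounds agree.

The compounds shown leave open what happens when the fluorophenyl on this nitrogen gives way to a different group, such as an unsubstituted phenyl, a methoxyphenyl or a cyclohexyl ring. They also leave open whether the three fluorophenyl compounds would separate in a full dose-response comparison.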